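Swapping a Benzimidazole Ether for a Piperazine Chain

The compounds below may be only part of what the source reports. "The series", "measured", "known", "first", "only" and "open" are said of these compounds alone.

Compound 1, with the structure `COc1c(OCc2nc3ccccc3[nH]2)cc(O)c2c(=O)cc(-c3ccccc3)oc12`, was tested in a functional assay on A549 cells (Homo sapiens) for cytotoxicity, read by MTT assay, with a stated time of 48 h; on this read-out lower numbers stand for stronger inhibition and higher numbers for weaker inhibition. In this assay compound 1 gives > 100000 nM, which is a limit of the assay and not a measured number. Compound 2, `CC(C)NCCOc1c(O)cc(O)c2c(=O)cc(-c3ccccc3)oc12`, has no result in this assay: "not determined" (no result reported). Compound 3, `COc1c(OCCCCN2CCN(C)CC2)cc(O)c2c(=O)cc(-c3ccccc3)oc12`, awaits measurement in this assay and differs from compound 1 in one place: 3-(4-methylpiperazin-1-yl)propyl in place of 1H-benzimidazol-2-yl on a saturated chain carbon bound to an oxygen on an aromatic ring. For the measured compounds named here, no measured step between related compounds exists, so the expected size rests on the step of an at least 1.6-fold lower number from compound 1 to compound 3 (0.22 log units; that floor lies within the scatter), estimated as small and toward stronger inhibition, barely beyond the scatter if at all. Compound 3 is estimated at 60000 nM, within 15000 nM to 200000 nM.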

Compound 3, half-maximal inhibitory concentration: 1500 nM
Estimate against measurement, compound 3: 40-fold (1.60 log units) above; measured number below the stated range.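

Changing the group on the saturated chain carbon bound to an oxygen on an aromatic ring clearly matters: in this assay this change gives an at least 66-fold lower number from compound 1 to compound 3 (1.82 log units; beyond the scatter) and shows that the shared core can reach a measurable effect. The true size of the step may be larger, because compound 1 stands at a limit of the assay and not at a number: the limit of > 100000 nM in this assay, at which 1 of the 3 values shown sits.

The compounds shown leave open whether the 4-methylpiperazin-1-yl ring or the propyl chain matters more. A morpholine ring or a dimethylamine on the same chain, or a shorter chain, could separate the two.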